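The compounds below may be only part of what the source reports. "The series", "measured", "known", "first", "only" and "open" are said of these compounds alone.

Three compounds of one series have been run in a functional assay on the whole organism (Tail, strain ICR) with Mus musculus as the target, in the tail flick test, with a stated time of 120 min, at a dose of 25 umol/kg by the oral route; on this read-out higher numbers stand for a stronger effect at the one dose given and lower numbers for a weaker effect. Compound 1 `O=C(O)[C@@H]1CCCN1C(=O)CN(c1nc(Cl)nc2[nH]cnc12)C1CC1` gives 23.6% in this assay. Compound 2 `O=C(CN(c1nc(Cl)nc2[nH]cnc12)C1CC1)NCC(=O)OCc1ccccc1` gives 21.7% in this assay, and compound 3 `C[C@H](NC(=O)CN(c1ncnc2c1ncn2C1CCCCO1)C1CC1)C(=O)OCc1ccccc1` gives 25.3% in this assay. The three numbers lie within the usual scatter of one another, so compound 2 cannot be set apart from either of the others on these data; its number simply sits alongside theirs. Among the measured compounds shown here, no pair among the measured compounds differs in only one place, so no single-change step is at hand to guide expectations.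

Compound 4 `NC(=O)C[C@H](NC(=O)CN(c1nc(Cl)nc2[nH]cnc12)C1CC1)C(=O)OCc1ccccc1` has not been measured. It differs from compound 2 by carbamoylmethyl in place of hydrogen on a saturated chain carbon bound to an amide-type nitrogen and a carbonyl carbon. Nothing in the measured set speaks to this kind of change, and the three measured compounds, which differ from one another in several places, all return numbers within the scatter of each other. The expected step is therefore a number 1.3 percentage points higher from compound 2 to compound 4 (within the scatter), in no direction beyond the scatter. Compound 4 is expected to give 23% in this assay, with a range from 10% to 38%.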

Compound 4, a percentage reported as activity, at one dose (the size of the read-out at that dose, not a potency): 15.1%
Compound 4: the middle estimate sits 7.9 percentage points above what was measured; the measured number falls inside the stated range.
By their numbers in this assay, from the lowest: compounds 4, 2, 1 and 3 (each within the scatter of the next, the first and the last beyond it).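

Among the compounds shown here, this is the first single-change step: in this assay, carbamoylmethyl in place of hydrogen on a saturated chain carbon bound to an amide-type nitrogen and a carbonyl carbon gives a number 6.6 percentage points lower from compound 2 to compound 4 (within the scatter), so the step does not separate compound 4 from compound 2. On this evidence, the position accepts carbamoylmethyl with no change beyond the scatter at the one dose and time given. Nothing available explains the number obtained for compound 4.

A single substituent at this carbon cannot show how the read-out responds to the group's size or character. A carboxylic acid or an amine on a longer chain at the same carbon would test whether this position stays as tolerant with other groups.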